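The source may report more compounds than this note shows. Statements on the series, on what has been measured and on what is new or still open speak of the compounds shown alone.

Compound 1 `Nc1ccccc1-c1cnc(C(=O)CCCCCCc2ccccc2)o1` gives 750 nM in an assay (Rattus norvegicus) for inhibition of Fatty-acid amide hydrolase 1 (Homo sapiens); a lower number here means a stronger inhibitor, a higher number a weaker inhibitor.
Compound 2 `O=C(CCCCCCc1ccccc1)c1ncc(-c2cccc(O)c2)o1` gives 50 nM in this assay.
Compound 3 `COC(=O)c1ccc(-c2cnc(C(=O)CCCCCCc3ccccc3)o2)cc1` gives 40 nM in this assay.

Among these three numbers compound 3 has the lowest; its gap to compound 2 lies within the usual scatter, so the two cannot be placed in order, while compound 1 sits far above both. For the measured compounds named here, the only step measured so far is a 15-fold lower number from compound 1 to compound 2 (1.18 log units; beyond the scatter), and it swaps one whole substituted ring for another.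

Compound 4 `N#Cc1ccc(-c2cnc(C(=O)CCCCCCc3ccccc3)o2)cc1` arises from compound 3 by a smaller change: cyano in place of methoxycarbonyl on an aromatic carbon. Going by the values given here, no measured step touches this kind of replacement, so nothing here says which way the number should move. With compound 3 and compound 2 already close together and the change confined to one small group on the outer ring, the expectation is a step of a 1.5-fold higher number from compound 3 to compound 4 (0.18 log units; within the scatter), not beyond the scatter. Compound 4 is therefore estimated at 60 nM in this assay, with a likely range from 15 nM to 250 nM.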

Compound 4, inhibition constant: 40 nM
Estimate against measurement, compound 4: 1.5-fold (0.18 log units) above; low and high end bracket the measured number.
By their numbers in this assay, from the lowest: compounds 3, 4 and 2 (each within the scatter of the next); then compound 1.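

In this assay, methoxycarbonyl (4 heavy atoms) gives way to cyano (2 heavy atoms) on an aromatic carbon para to a large group, with no change at the digits printed from compound 3 to compound 4 (within the scatter), so this position accepts a much smaller group with a triple bond in place of one with a double bond. Comparing whole substituted rings, there is a 1.3-fold lower number from compound 2 to compound 4 (0.10 log units; within the scatter), whereas there is a 19-fold lower number from compound 1 to compound 4 (1.27 log units; beyond the scatter), which leaves the 2-aminophenyl ring as the only one of the four standing apart. Nothing measured here explains why these groups give such similar numbers.

Open, going by these compounds, is whether a carboxylic acid at this same carbon, or a bare ring with no group there, would stay level with cyano and methoxycarbonyl. Also open, on these data alone, is whether a 4-aminophenyl ring would match the 2-aminophenyl ring or the 4-cyanophenyl ring.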